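This account rests on a few compounds, and the source may have more. Where it says the series, first, only, none or still open, it means among the compounds named here.

Of the compounds shown here, two that share one core have so far been measured in an ADME assay on Vero cells (Chlorocebus sabaeus) for cytotoxicity, read by neutral red uptake, tested at 394 ug/mL; a lower number here means a stronger effect, a higher number a weaker effect of the compound at the concentration tested. Compound 1 `O=C1CSC(c2cccc(F)c2)N1CCN1CCCCC1` gives 60%, while compound 2 `O=C1CSC(c2ccc(Cl)cc2)N1CCN1CCCCC1` gives 28%, the lowest of the two numbers. Within the data shown here, the single step recorded so far, a number 32 percentage points lower from compound 1 to compound 2 (beyond the scatter), came with 4-chlorophenyl in place of 3-fluorophenyl on a saturated ring carbon. Compound 3 `COc1ccc(C2SCC(=O)N2CCN2CCCCC2)cc1` has not yet been tested in this assay; it differs from compound 2 by methoxy in place of chloro on an aromatic carbon. Among the measured compounds shown here, no measured step exchanges chloro for methoxy, and the only step available, a number 32 percentage points lower from compound 1 to compound 2 (beyond the scatter), altered both the halogen and where it sits, so it bears on this change only loosely. For the measured compounds named here, the expectation is therefore a modest rise from compound 2 toward the middle of the two known numbers, an estimated step of a number 17 percentage points higher from compound 2 to compound 3 (beyond the scatter). For compound 3 in this assay the estimate is 45%, expected to fall between 20% and 70%.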

Compound 3, a percentage reported as activity, at one concentration (the size of the read-out at that concentration, not a potency): 73%
The estimate for compound 3 lay 28 percentage points below the measured number; measured number above the stated range.
By their numbers in this assay, from the lowest: compound 2; then compound 1; then compound 3.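

In this assay, the step at this aromatic carbon, para to a large group, changes one group while the place stays fixed: methoxy in place of chloro gives a number 45 percentage points higher from compound 2 to compound 3 (beyond the scatter) and moves the number toward a weaker effect. The earlier step, a number 32 percentage points lower from compound 1 to compound 2 (beyond the scatter), altered both the halogen and where it sits, so it could not show that exchanging the group at this one place is enough for a change beyond the scatter. No measurement of any property accompanies these compounds that would account for the result.

From the compounds shown here alone, it remains open whether other groups at this place, such as a hydroxyl, an amine or a carboxylic acid, would stay close to chloro or to methoxy. Also open, going by these compounds, is how methoxy would behave on another aromatic carbon of the same ring.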